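This account rests on a few compounds, and the source may have more. Where it says the series, first, only, none or still open, it means among the compounds named here.

Of the compounds shown here, three built on one shared core have been tested in a functional assay on HCT-116 cells (Homo sapiens) for antiproliferative activity, read by MTT assay; a lower number here means a stronger inhibitor, a higher number a weaker inhibitor. Compound 1 `Cn1c(=O)c(=O)n(C2CCCC2)c2nc(N/N=C/c3ccc(O)cc3)ncc21` gives 72500 nM. Compound 2 `Cc1cc(C)c(/C=N/Nc2ncc3c(n2)n(C2CCCC2)c(=O)c(=O)n3C)c(C)c1` gives 7920 nM, the lowest of the three numbers. Compound 3 `COc1cc(/C=N/Nc2ncc3c(n2)n(C2CCCC2)c(=O)c(=O)n3C)cc(OC)c1OC` gives 22900 nM, which sits between the other two. The group on the carbon with a double bond to nitrogen clearly matters: swapping it gave a 9.2-fold lower number from compound 1 to compound 2 (0.96 log units; beyond the scatter).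

Compound 4 `Cn1c(=O)c(=O)n(C2CCCC2)c2nc(N/N=C/c3ccccc3Cl)ncc21` has not yet been measured in this assay. Compared with compound 2, (2-chlorophenyl in place of 2,4,6-trimethylphenyl on a carbon with a double bond to nitrogen). Going by the values given here, only the step from compound 1 to compound 2 bears directly on this place, and it was modest; a moderate rise beyond the scatter is therefore expected for compound 4. The estimate for compound 4 is 15000 nM, with a range from 5000 nM to 45000 nM, an expected step of a 1.9-fold higher number from compound 2 to compound 4 (0.28 log units; within the scatter).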

Compound 4, half-maximal inhibitory concentration: 14000 nM
Compound 4: the middle estimate sits 1.1-fold (0.03 log units) above what was measured; low and high end bracket the measured number.
By their numbers in this assay, from the lowest: compounds 2, 4 and 3 (each within the scatter of the next, the first and the last beyond it); then compound 1.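

In this assay, putting 2-chlorophenyl in place of 2,4,6-trimethylphenyl on the carbon with a double bond to nitrogen gives a 1.8-fold higher number from compound 2 to compound 4 (0.25 log units; within the scatter), so these two groups cannot be told apart here. Putting 2-chlorophenyl in place of 4-hydroxyphenyl gives a 5.2-fold lower number from compound 1 to compound 4 (0.71 log units; beyond the scatter), which shows that the lower number seen earlier does not depend on the three methyl groups. Nothing available explains these differences. Still open, on these data alone, is how a plain phenyl would compare with these groups. So is the effect of carrying an amine or a carboxylic acid on the ring at this place.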